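This account rests on a few compounds, and the source may have more. Where it says the series, first, only, none or still open, it means among the compounds named here.

Compound 3 `O=C(/C=C/c1cccc(Br)c1)c1cccc(-c2cccc(F)c2)c1` holds the lowest of the two numbers seen so far in an assay on A549 cells for inhibition of transcription factor p65 (Homo sapiens), read by fluorescence, with a stated time of 2 h; a lower number here means a stronger inhibitor, a higher number a weaker inhibitor: compound 3 gives 11200 nM there. Compound 2 `COc1cccc(/C=C/C(=O)c2cccc(-c3cccc(F)c3)c2)c1OC`, which carries two methoxy groups on the aryl of the chain, gives 24100 nM in this assay, a higher number than compound 3 shows. Compound 1 `O=C(/C=C/c1ccc(Br)cc1)c1cccc(-c2cccc(F)c2)c1` reaches only a limit in this assay, with a value given as > 50000 nM; this is the limit of > 50000 nM in this assay, at which 1 of the 3 values shown sits. Among the compounds with values here, the single measured step connects compounds 1 and 3, where the bromine was moved: an at least 4.4-fold lower number from compound 1 to compound 3 (0.64 log units; beyond the scatter).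

Compound 4 `COc1ccccc1/C=C/C(=O)c1cccc(-c2cccc(F)c2)c1` is the next member to be tested. Relative to compound 3 it shows the change (2-methoxyphenyl in place of 3-bromophenyl on a double-bonded chain carbon bound to a double-bonded chain carbon). Within the data shown here, no measured step exchanges a bromine for a methoxy, so the one step that exists, from a 4-bromophenyl to a 3-bromophenyl, bears on it only loosely, and the comparison of compound 2 with compound 3 gives no more than two numbers. A modest rise in the number beyond the scatter is therefore expected, in the direction of weaker inhibition, and the step from compound 3 to compound 4 is estimated at a 1.8-fold higher number from compound 3 to compound 4 (0.25 log units; within the scatter). Compound 4 is accordingly expected to give about 20000 nM in this assay, within a range from 8000 nM to 50000 nM.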

Compound 4, half-maximal inhibitory concentration: 35300 nM
For compound 4 the middle estimate is 1.8-fold (0.25 log units) below the measured one, within the range that was stated.
By their numbers in this assay, from the lowest: compound 3; then compounds 2 and 4 (each within the scatter of the next). At a limit, above all of these: compound 1.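

In this assay, within the data shown here, the 2-methoxyphenyl group gives the first single exchange of a bromine-bearing aryl for a methoxy-bearing aryl on a double-bonded chain carbon bound to a double-bonded chain carbon, and the step is a loss beyond the scatter: a 3.2-fold higher number from compound 3 to compound 4 (0.50 log units; beyond the scatter). The second methoxy group of compound 2 makes no difference that can be read, with a 1.5-fold higher number from compound 2 to compound 4 (0.17 log units; within the scatter), so compound 3 keeps the lowest number of the series and its 3-bromophenyl group remains the best of the aryl groups shown at this place. The comparison of compound 4 with compound 1 yields only a floor, an at least 1.4-fold lower number from compound 1 to compound 4 (0.15 log units; that floor lies within the scatter), which does not order the two compounds, and compound 1 stands at a limit: the limit of > 50000 nM in this assay, at which 1 of the 4 values shown sits.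

The compounds shown leave open whether the gap between compound 3 and compound 4 follows from the exchange of bromine for methoxy or from where the group sits on the aryl. They also leave open whether an amine or a carboxylic acid on this aryl, in place of the bromine of compound 3, would keep or lower its number.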